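Dimethylpiperidinyl sulfonyl in place of phenylethenyl

The compounds below may be only part of what the source reports. "The series", "measured", "known", "first", "only" and "open" are said of these compounds alone.

Compound 2 `C=C(c1ccccc1)c1ccc2c(c1)[C@@H](/N=C(\NC#N)Nc1ccc(Cl)cc1)[C@H](O)C(C)(C)O2` is read in a functional assay (aorta) with Rattus norvegicus as the target (on this read-out higher numbers stand for weaker inhibition and lower numbers for stronger inhibition), where compound 2 gives 10700 nM. On the numbers shown compound 2 sits with compound 1 `CC1(C)Oc2ccc(Cc3ccccc3)cc2[C@@H](/N=C(\NC#N)Nc2ccc(Cl)cc2)[C@@H]1O` within the scatter, compound 1 giving 10000 nM in this assay, and both stand well apart from compound 3 `CC1(C)Oc2ccc(S(=O)(=O)N3CCCCC3)cc2[C@@H](/N=C(\NC#N)Nc2ccc(Cl)cc2)[C@@H]1O`, for which this assay returns 1900 nM.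

The next step leads to compound 4 `CC1CC(C)CN(S(=O)(=O)c2ccc3c(c2)[C@@H](/N=C(\NC#N)Nc2ccc(Cl)cc2)[C@H](O)C(C)(C)O3)C1`. (3,5-dimethylpiperidin-1-yl)sulfonyl in place of 1-phenylethenyl on an aromatic carbon

Among the measured compounds shown here, three measured steps bear on this. The replacement of the same group by the unsubstituted (piperidin-1-yl)sulfonyl gave a 5.6-fold lower number from compound 2 to compound 3 (0.75 log units; beyond the scatter), and the parallel change from the benzyl analogue gave a 5.3-fold lower number from compound 1 to compound 3 (0.72 log units; beyond the scatter); the swap between the two hydrocarbon groups, a 1.1-fold higher number from compound 1 to compound 2 (0.03 log units; within the scatter), stayed within the scatter. For the measured compounds named here, no measured pair shows what the two methyl groups on the piperidine ring add or take away, so their contribution is unknown.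

The expectation is therefore a step of roughly the size seen for compound 3, in the direction of a lower number, that is a 5.9-fold lower number from compound 2 to compound 4 (0.77 log units; beyond the scatter). For compound 4 in this assay the estimate is 1800 nM, with a range from 600 nM to 5500 nM that allows for the untested methyl groups.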

Compound 4, half-maximal inhibitory concentration: 32100 nM
For compound 4 the middle estimate is 18-fold (1.25 log units) below the measured one; the measured number lies above the stated range.
By their numbers in this assay, from the lowest: compound 3; then compounds 1 and 2 (each within the scatter of the next); then compound 4.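

In this assay the (piperidin-1-yl)sulfonyl group is not a fixed advantage at this aromatic carbon: adding the two methyl groups of 3,5-dimethylpiperidin-1-yl on the sulfonyl sulfur gives a 17-fold higher number from compound 3 to compound 4 (1.23 log units; beyond the scatter), the largest step among the compounds shown. The lower number seen for compound 3 is therefore not carried by the sulfonyl link alone, and against the two hydrocarbon groups the direction reverses, with a 3.0-fold higher number from compound 2 to compound 4 (0.48 log units; beyond the scatter) and a 3.2-fold higher number from compound 1 to compound 4 (0.51 log units; beyond the scatter). So the outer part of the sulfonyl substituent matters here at least as much as the replacement of 1-phenylethenyl or benzyl itself, and no supporting measurement is available to account for this reversal.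

Still open, from the compounds shown here alone, is whether a single methyl group on the piperidine ring already moves the number upward or whether the step needs both methyl groups. Also open, going by these compounds, is how a smaller pyrrolidine ring, a morpholine ring or an open-chain dimethylamino group on the same sulfonyl sulfur would read against compound 3 and compound 4.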